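Series notes: hexyl to 3-hydroxyphenyl on the chain

The source may hold more compounds than are shown below. What is called first, only, known or untested is meant among the compounds shown, and "the series" means these compounds.

Three compounds of the shared core have numbers in a functional assay on HeLa cells (Homo sapiens) for cytotoxicity, read by WST assay, with a stated time of 48 h; on this read-out higher numbers stand for weaker inhibition and lower numbers for stronger inhibition. Compound 1 `CCCCCC/C=C/C[C@H]1C[C@@H]([C@@H](O)c2ccccc2)CO[C@@H]1c1ccccc1` gives 7400 nM in this assay, the lowest of the three numbers. Compound 2 `COc1cccc([C@H](O)[C@H]2CO[C@H](c3ccc(OC)c(OC)c3)[C@@H](C/C=C/c3ccc(OC)c(OC)c3)C2)c1` gives 21200 nM in this assay, a higher number than compound 1 beyond the scatter. Compound 3 `COc1ccc(CCC[C@@H]2C[C@@H]([C@@H](O)c3ccc(OC)c(OC)c3)CO[C@H]2c2ccc(OC)c(OC)c2)cc1OC` gives 35700 nM in this assay, again a higher number than compound 1 beyond the scatter. No pair among these three differs in one place only, so no single step is known.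

Compound 4 `Oc1cccc(/C=C/C[C@H]2C[C@@H]([C@@H](O)c3ccccc3)CO[C@@H]2c2ccccc2)c1` has not been measured in this assay. It differs from compound 1 in one place: 3-hydroxyphenyl in place of hexyl on a double-bonded chain carbon bound to a double-bonded chain carbon The two measured compounds carrying an aromatic ring on the chain, compound 2 and compound 3, both show higher numbers than compound 1. Within the data shown here, they also differ from compound 1 elsewhere, so no step for the chain alone is known.

For compound 4 a step of a 1.4-fold higher number from compound 1 to compound 4 (0.13 log units; within the scatter) is expected, a small move toward a higher number that may not exceed the scatter. The estimate for compound 4 in this assay is 10000 nM, in the range 3000 nM to 33000 nM, because compound 1 gives 7400 nM and nothing measured points to a large move in either direction.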

Compound 4, half-maximal inhibitory concentration: 18600 nM
Estimate against measurement, compound 4: 1.9-fold (0.27 log units) below; low and high end bracket the measured number.
By their numbers in this assay, from the lowest: compound 1; then compounds 4, 2 and 3 (each within the scatter of the next).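

In this assay the chain position now has its first single step: 3-hydroxyphenyl in place of hexyl on a double-bonded chain carbon bound to a double-bonded chain carbon gives a 2.5-fold higher number from compound 1 to compound 4 (0.40 log units; beyond the scatter) and counts as a modest move beyond the scatter. The number at this position therefore responds to this exchange with the rest of compound 1 unchanged, which compound 2 and compound 3 could not show, as they differ from compound 1 elsewhere too. No measurement bears on why the number moves, and this one step does not separate the aromatic ring from the hydroxyl.

Open, on these data alone, is whether a plain phenyl, an aminophenyl or an octyl chain in the same place would move the number as 3-hydroxyphenyl does. Also open, as far as these compounds go, is whether this exchange would give a similar step on cores carrying methoxy groups.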